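The source may report more compounds than this note shows. Statements on the series, on what has been measured and on what is new or still open speak of the compounds shown alone.

- Compound 1 `CCOC(=O)Cn1ncc2c(Nc3ccc(NC(=O)CCl)cc3)ncnc21` in a functional assay on cells (Homo sapiens) for inhibition, read by MTT assay, with a stated time of 72 h; on this read-out lower numbers stand for stronger inhibition and higher numbers for weaker inhibition: 3.51 ug/mL
- Compound 2 `CCOC(=O)Cn1ncc2c(Nc3ccc(NS(=O)(=O)c4ccc(Br)cc4)cc3)ncnc21` in this assay: > 64 ug/mL, a limit and not a number

For the measured compounds named here, compound 1 holds the only true number so far, so its standing rests on a single comparison. Compound 3 `O=C(O)Cn1ncc2c(Nc3ccc(NC(=O)CCl)cc3)ncnc21` keeps the core and the (chloromethyl)carbonyl of compound 1. The change lies elsewhere: hydrogen in place of ethyl on an oxygen next to a carbonyl group, with hydrogen in place of ethyl on an oxygen next to a carbonyl group, so that ethoxycarbonyl becomes carboxy. Going by the values given here, the one measured step, an at least 18-fold higher number from compound 1 to compound 2 (1.26 log units; beyond the scatter), was large, but it replaced the (chloromethyl)carbonyl on a nitrogen and left this oxygen untouched. It therefore offers no direct guide here. Starting from compound 1 at 3.51 ug/mL, a modest move toward weaker inhibition in this assay is expected, though a result within the scatter remains possible. The expected size is a 2.8-fold higher number from compound 1 to compound 3 (0.45 log units; beyond the scatter). Compound 3 is estimated at 10 ug/mL, with an expected range of 3 ug/mL to 40 ug/mL.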

Compound 3, half-maximal inhibitory concentration: > 100 ug/mL
Compound 3 ended at the assay's limit (the forecaster's own chance of this, stated with the estimate: 10%); at least 10-fold (1.00 log units) between middle value and limit.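

Until now, only a change at the (chloromethyl)carbonyl on a nitrogen had been seen to matter, whereas this result shows that the other end of compound 1 matters too. With the core and the (chloromethyl)carbonyl kept, hydrogen in place of ethyl on this oxygen, turning ethoxycarbonyl into carboxy, gives an at least 28-fold higher number from compound 1 to compound 3 (1.45 log units; beyond the scatter). Compound 3 stands at > 100 ug/mL in this assay, which is a limit and not a number, so how much weaker it truly is stays unknown: the limit of > 100 ug/mL in this assay, at which 1 of the 3 values shown sits.

One pair cannot tell whether the loss comes from removing the ethyl or from having a free carboxy. Methoxycarbonyl, a longer chain such as propoxycarbonyl, or a primary amide in this place would help separate those two readings.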